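Swapping a sulfonyl aryl group on a thiadiazole series

A few compounds are considered here, and "the series" means these few. Any claim that something is new, unique, unknown or untested is made for them only; others in the source may bear on it.

Measured so far:
compound 1 `COc1ccc(Cc2nnc(NC(=O)/C(C#N)=C/c3ccccc3OS(=O)(=O)c3ccccc3[N+](=O)[O-])s2)cc1`, 18%
compound 2 `COc1ccc(Cc2nnc(NC(=O)/C(C#N)=C/c3ccccc3OS(=O)(=O)c3ccc(Cl)cc3)s2)cc1`, 34%
compound 3 `N#C/C(=C\c1ccccc1OS(=O)(=O)c1ccccc1[N+](=O)[O-])C(=O)Nc1nnc(Cc2cccc3ccccc23)s1`, "not toxic" (no number reported)

In an ADME assay on HEK-293T cells (Homo sapiens) for inhibition, read by CCK-8 assay, with a stated time of 48 h, tested at 20 uM (a higher number here means more inhibition of growth at the concentration tested, a lower number less inhibition of growth), compound 1 gives 18% and compound 2 gives 34%. The change between them is 4-chlorophenyl in place of 2-nitrophenyl on a sulfonyl sulfur, and the step is a number 16 percentage points higher from compound 1 to compound 2 (beyond the scatter). Compound 3 differs from compound 1 in its core: naphthalen-1-yl in place of 4-methoxyphenyl on a saturated chain carbon bound to an aromatic carbon. For compound 3 the result in this assay is "not toxic" (no number reported), with no single number reported. Compound 4 `N#C/C(=C\c1ccccc1OS(=O)(=O)c1ccc(Cl)cc1)C(=O)Nc1nnc(Cc2cccc3ccccc23)s1` is not yet measured and differs from compound 3 by 4-chlorophenyl in place of 2-nitrophenyl on a sulfonyl sulfur, the same change as from compound 1 to compound 2. A step of similar modest size is expected here, resting only on a number 16 percentage points higher from compound 1 to compound 2 (beyond the scatter); it starts from an unknown low point, so compound 4 is estimated at 20% in this assay, within 5% to 40%.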

Compound 4, percent growth inhibition at one concentration: 16%
Estimate against measurement, compound 4: 4 percentage points above; the measured number falls inside the stated range.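

In this assay, with the 4-chlorophenyl group held fixed on the sulfonyl sulfur, naphthalen-1-yl in place of 4-methoxyphenyl gives a number 18 percentage points lower from compound 2 to compound 4 (beyond the scatter). From the compounds shown here alone, compound 3 has no number, so the swap of 2-nitrophenyl for 4-chlorophenyl cannot be read on the naphthalen-1-yl core, and it remains unknown whether the step seen on the other core, a number 16 percentage points higher from compound 1 to compound 2 (beyond the scatter), carries over. No measurement shown here accounts for the difference between compound 2 and compound 4.

Still open, going by these compounds, is how other groups on the sulfonyl sulfur, such as a plain phenyl or a methyl, would behave in this assay. Also open, on these data alone, is what a carboxylic acid or an amine on the aromatic ring of the chain would do.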